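The source may hold more compounds than are shown below. What is called first, only, known or untested is meant among the compounds shown, and "the series" means these compounds.

Measured compounds:
- compound 1, `C#CCn1cc(C(=O)NC(CC(=O)Nc2ccccn2)c2ccccc2)c(=O)c2ccc(Cl)nc21`: "not active" (no number reported)
- compound 2, `C#CCn1cc(C(=O)NC(CC(=O)Nc2ccccc2)c2ccccc2)c(=O)c2ccc(Cl)nc21`: 4400 nM

In an ADME assay on NIH3T3 cells (Mus musculus) for cytotoxicity, read by MTT assay, with a stated time of 72 h (on this read-out lower numbers stand for stronger inhibition and higher numbers for weaker inhibition), compound 2 gives 4400 nM. For the measured compounds named here, this is the only number in the set, so compound 2 stands alone and cannot be ranked against anything. Compound 1, with its own structure shown above, is reported in this assay only as "not active" (no number reported), without a number, so nothing can be said about how far it sits from compound 2.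

Compound 3, `C#CCn1cc(C(=O)NC(CC(=O)NC2CCCC2)c2ccccc2)c(=O)c2ccc(Cl)nc21`, is not yet measured. It differs from compound 2 in one place: cyclopentyl in place of phenyl on an amide-type nitrogen, where the other neighbour of that nitrogen is a carbonyl carbon. Going by the values given here, no pair of measured compounds shows what such a swap does in this assay, so the expected step rests on compound 2 alone.

The step from compound 2 to compound 3 is expected to stay within the usual scatter, or to move a little toward weaker inhibition, as a 1.4-fold higher number from compound 2 to compound 3 (0.13 log units; within the scatter). Compound 3 is therefore estimated at 6000 nM in this assay, within a range from 2000 nM to 20000 nM.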

Compound 3, half-maximal inhibitory concentration: 4400 nM
Compound 3: middle estimate off by 1.4-fold (0.13 log units), on the high side; measured number inside the range.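

In this assay, for the compounds shown here, cyclopentyl in place of phenyl on an amide-type nitrogen gives no change at the digits printed from compound 2 to compound 3 (within the scatter) and so provides the first readable step at this position. The change replaces a six-membered aromatic ring of carbon only with a five-membered non-aromatic ring of carbon only, yet for this pair the loss of the aromatic ring does not show in the read-out. Nothing measured here explains why the two compounds read alike.

Compound 1 carries no number, so its step to compound 2 cannot be read, and the effect of its ring at this position remains unclear. One swap between two carbon rings also leaves open what happens with other groups on this nitrogen, such as a straight hexyl chain, or a cyclopentyl ring bearing a carboxylic acid or an amine, which would show whether this read-out stays the same once the group is no longer made of carbon alone.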